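The compounds below may be only part of what the source reports. "The series", "measured", "known", "first", "only" and "open" are said of these compounds alone.

Measured in a functional assay on MCF7 cells (Homo sapiens) for cytotoxicity, read by sulforhodamine B assay, with a stated time of 48 h; a lower number here means a stronger inhibitor, a higher number a weaker inhibitor:
- compound 1 `C=CCOc1ccc(F)cc1C(=O)c1cccnc1`: > 100000 nM
- compound 2 `C=CCOc1cc(Br)ccc1C(=O)c1cccnc1`: > 100000 nM

Compound 1 stands at the limit of > 100000 nM in this assay, at which 2 of the 2 values shown sit. Its reading of > 100000 nM is a limit and not a number. The reading of > 100000 nM for compound 2 is also a limit. Compound 3 `O=C(c1cccnc1)c1cc(F)ccc1O` follows from compound 1 by hydrogen in place of allyl on an oxygen on an aromatic ring, allyloxy to hydroxy. Within the data shown here, no measured step in this assay gives a size for this change. The expected change is small, toward a lower number or none beyond the scatter: an at least 1.1-fold lower number from compound 1 to compound 3 (0.04 log units; that floor lies within the scatter). For compound 3 the estimated value is 90000 nM, with an expected range of 30000 nM to 200000 nM.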

Compound 3, half-maximal inhibitory concentration: 27800 nM
Compound 3: middle estimate off by 3.2-fold (0.51 log units), on the high side, outside the stated range (below it).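

In this assay, hydrogen in place of allyl on an oxygen on an aromatic ring gives an at least 3.5-fold lower number from compound 1 to compound 3 (0.55 log units; beyond the scatter), so this position can carry a change that moves the reading. Compound 3 is the first compound shown with a measured number rather than a limit. On these data alone, the true size of the step remains unknown because compound 1 rests on a limit: the limit of > 100000 nM in this assay, at which 2 of the 3 values shown sit.

As far as these compounds go, whether a methoxy or an amine at this position would match the hydroxy remains open. So does whether the same change would lower the reading of compound 2, the bromo compound.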